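A few compounds are considered here, and "the series" means these few. Any claim that something is new, unique, unknown or untested is made for them only; others in the source may bear on it.

In a functional assay on A549 cells (Homo sapiens) for antiproliferative activity, read by MTT assay, with a stated time of 48 h (on this read-out lower numbers stand for stronger inhibition and higher numbers for weaker inhibition), the work compares compounds that share one core and differ in a single group on a double-bonded ring carbon. Compound 1, `CC(C)=CCC[C@]1(C)/C=C/[C@@H](OC(=O)C=C(C)C)[C@](C)(O)/C=C/C(=O)/C(C(=O)O)=C\C1`, gives > 10000 nM, which is a limit of the assay and not a number. Compound 2, `CSC(=S)OC/C1=C/C[C@](C)(CCC=C(C)C)/C=C/[C@@H](OC(=O)C=C(C)C)[C@](C)(O)/C=C/C1=O`, gives 380 nM. Compound 3, `CO/N=C/C1=C/C[C@](C)(CCC=C(C)C)/C=C/[C@@H](OC(=O)C=C(C)C)[C@](C)(O)/C=C/C1=O`, gives 3470 nM, the higher of the two actual numbers, and the gap is a 9.1-fold higher number from compound 2 to compound 3 (0.96 log units; beyond the scatter).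

Compound 4, `CC(C)=CCC[C@]1(C)/C=C/[C@@H](OC(=O)C=C(C)C)[C@](C)(O)/C=C/C(=O)/C(C(=O)N(C(C)C)C(C)C)=C\C1`, changes this same place: a group of 9 heavy atoms (7 carbon, 1 nitrogen, 1 oxygen; no ring) in place of a group of 4 heavy atoms (2 carbon, 1 nitrogen, 1 oxygen; no ring), on a double-bonded ring carbon. The entering group is diisopropylcarbamoyl. Going by the values given here, three measured steps bear on the change, and all lie beyond the scatter: an at least 26-fold lower number from compound 1 to compound 2 (1.42 log units; beyond the scatter), an at least 2.8-fold lower number from compound 1 to compound 3 (0.45 log units; beyond the scatter) and the gap already given. The numbers at this place therefore span a wide range across these three compounds. None of them carries diisopropylcarbamoyl, so they fix no firm direction. Like compound 1, at > 10000 nM, compound 4 joins its group to the ring through a carbonyl, which tilts the expectation slightly towards weaker inhibition in this assay. The estimated step is a 1.4-fold higher number from compound 3 to compound 4 (0.16 log units; within the scatter). For compound 4 the expected value is 5000 nM, with an estimated range of 1200 nM to 16000 nM.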

Compound 4, half-maximal inhibitory concentration: 13500 nM
Compound 4: middle estimate off by 2.7-fold (0.43 log units), on the low side; low and high end bracket the measured number.
By their numbers in this assay, from the lowest: compound 2; then compound 3; then compound 4.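

In this assay, the diisopropylcarbamoyl group gives this double-bonded ring carbon its first carbonyl-linked group with an actual number, and that number lies at the weak end of the measured series, with a 3.9-fold higher number from compound 3 to compound 4 (0.59 log units; beyond the scatter) and a 36-fold higher number from compound 2 to compound 4 (1.55 log units; beyond the scatter). The numbers do not follow the size of the group: compound 2 carries a larger group than compound 3 and has the lower number, while compound 4 carries the largest group and has the highest of the three actual numbers. The step from compound 1 to compound 4 cannot be read, because compound 1 stands at a limit of the assay and not at a number: the limit of > 10000 nM in this assay, at which 1 of the 4 values shown sits.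

The compounds shown do not separate the effect of the carbonyl link from that of the two isopropyl groups, which a dimethylcarbamoyl group, an unsubstituted carboxamide or a methyl ester at this place could help to do. Going by these compounds alone, they also leave open whether the lower number of compound 2 belongs to its sulfur-bearing group as a whole, since no oxygen analogue such as a methyl carbonate is among them.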